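The compounds below may be only part of what the source reports. "The series", "measured", "known", "first", "only" and "open" are said of these compounds alone.

Working notes on the series. The read-out throughout is an assay on isolated protein (strain Sprague-Dawley) for inhibition of Amine oxidase [flavin-containing] B (Rattus norvegicus), read by spectrophotometry, with a stated time of 5 min; on this read-out lower numbers stand for stronger inhibition and higher numbers for weaker inhibition. Compound 1 `CCOc1cc(=O)oc2cc(OCc3cccc(F)c3)ccc12` gives 263 nM, compound 2 `COCOc1cc(=O)oc2cc(OCc3cccc(Cl)c3)ccc12` gives 100 nM, and compound 3 `NC(=O)COc1cc(=O)oc2cc(OCc3cccc(Br)c3)ccc12` gives 8.91 nM. Among these three numbers compound 2 stands second highest: the nearest is compound 1, whose number is higher and beyond the scatter, and the furthest is compound 3, whose number is lower and well beyond the scatter. For the measured compounds named here, the three differ from each other in more than one place, so no single-point step between measured compounds is available.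

Compound 4 `CCNc1cc(=O)oc2cc(OCc3cccc(Cl)c3)ccc12` is not yet measured. Relative to compound 2 the change is ethylamino in place of methoxymethoxy on an aromatic carbon. Going by the values given here, nothing among the measured compounds isolates this exchange, so the direction of the step is open. The working expectation is a step from compound 2 to compound 4 of about a 2.0-fold higher number from compound 2 to compound 4 (0.30 log units; within the scatter), which would fall within the scatter. On that basis compound 4 is estimated at 200 nM in this assay, with a range from 40 nM to 1000 nM.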

Compound 4, half-maximal inhibitory concentration: 28.2 nM
Compound 4: the middle estimate sits 7.1-fold (0.85 log units) above what was measured, outside the stated range (below it).
By their numbers in this assay, from the lowest: compound 3; then compound 4; then compound 2; then compound 1.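

In this assay, for the compounds shown here, ethylamino in place of methoxymethoxy, on an aromatic carbon opposite the ring oxygen, gives a 3.5-fold lower number from compound 2 to compound 4 (0.55 log units; beyond the scatter), the first step that isolates a single change. This shows that the number responds to the group at this position, with a step beyond the scatter. The exchange alters more than one feature at once: ethylamino has fewer heavy atoms, links through nitrogen rather than oxygen, and carries a hydrogen-bond donor where methoxymethoxy has none, and nothing available bears on which of these matters.

Whether the nitrogen link, the donor or the chain accounts for the step remains open. A plain amino group and a dimethylamino group at this position would help separate these features, and the compounds shown do not yet settle the question.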